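A few compounds are considered here, and "the series" means these few. Any claim that something is new, unique, unknown or untested is made for them only; others in the source may bear on it.

Within the data shown here, compound 1 `O=C(Nc1ccccc1[N+](=O)[O-])N[C@H]1CC[C@H](Oc2ccc(F)cc2)CC1` gives 3500 nM in a functional assay on CRL2813 cells (Homo sapiens) for cytotoxicity, read by sulforhodamine B assay, with a stated time of 5 days (a lower number here means a stronger inhibitor, a higher number a weaker inhibitor), the only plain number so far. Compound 2 `O=C(Nc1ccccc1C(F)(F)F)N[C@H]1CC[C@H](Oc2ccc(F)cc2)CC1`, which carries trifluoromethyl in place of nitro on an aromatic carbon, is reported only as a limit of the assay, > 20000 nM. Compound 2 thus stands at the limit of > 20000 nM in this assay, at which 1 of the 2 values shown sits. Among the measured compounds shown here, the one measured step is an at least 5.7-fold higher number from compound 1 to compound 2 (0.75 log units; beyond the scatter). Compound 3 `CSc1cccc(NC(=O)N[C@H]2CC[C@H](Oc3ccc(F)cc3)CC2)c1` differs from compound 1 by 3-(methylsulfanyl)phenyl in place of 2-nitrophenyl on an amide-type nitrogen. Here too the nitro group leaves, so a weakening of comparable size is expected, a 3.4-fold higher number from compound 1 to compound 3 (0.54 log units; beyond the scatter). Compound 3 is therefore estimated at 12000 nM, between 3500 nM and 40000 nM.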

Compound 3, half-maximal inhibitory concentration: 11100 nM
The estimate for compound 3 lay 1.1-fold (0.03 log units) above the measured number; measured number inside the range.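

In this assay, 3-(methylsulfanyl)phenyl in place of 2-nitrophenyl on the amide-type nitrogen gives a 3.2-fold higher number from compound 1 to compound 3 (0.50 log units; beyond the scatter), so at this position losing the nitro group still leaves a plain number, and the replacement group decides how far the value moves. Compound 2, by contrast, is reported only as a limit of the assay, > 20000 nM. Nothing shown here bears on why the step occurs. The compounds shown leave open how an amine or a carboxylic acid on the phenyl ring would read at this nitrogen.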